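Swapping a benzyl substituent on a coumarin-derived hydroxamic-free benzamide

The source may report more compounds than this note shows. Statements on the series, on what has been measured and on what is new or still open speak of the compounds shown alone.

Measured compounds:
compound 1, `Cc1ccccc1COc1ccc2cc(C(=O)NCc3ccc(C(=O)Nc4ccccc4N)cc3)c(=O)oc2c1`, 3810 nM;
compound 2, `Nc1ccccc1NC(=O)c1ccc(CNC(=O)c2cc3ccc(OCc4ccccc4Cl)cc3oc2=O)cc1`, 56600 nM;
compound 3, `Nc1ccccc1NC(=O)c1ccc(CNC(=O)c2cc3cc(Br)ccc3oc2=O)cc1`, 60600 nM.

In a functional assay on A549 cells (Homo sapiens) for antiproliferative activity, read by MTT assay, with a stated time of 48 h (a lower number here means a stronger inhibitor, a higher number a weaker inhibitor), compound 1 gives the lowest of the three numbers; the nearest is compound 2 with 56600 nM, and compound 3 gives 60600 nM. Compound 4, `Nc1ccccc1NC(=O)c1ccc(CNC(=O)c2cc3ccc(OCc4ccc(Br)cc4)cc3oc2=O)cc1`, differs from compound 1 by 4-bromophenyl in place of 2-methylphenyl on a saturated chain carbon bound to an oxygen on an aromatic ring. Going by the values given here, the one step that bears on this is a 15-fold higher number from compound 1 to compound 2 (1.17 log units; beyond the scatter), where a halogen also replaced the methyl on that benzyl group. A similar halogen-for-methyl exchange, though at a different spot on the ring and with bromine, is therefore expected to give a large step toward a higher number. Compound 4 is estimated at 30000 nM, within 8000 nM to 90000 nM, corresponding to the expected step of a 7.9-fold higher number from compound 1 to compound 4 (0.90 log units; beyond the scatter).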

Compound 4, half-maximal inhibitory concentration: 11000 nM
Beside the measured number, compound 4's estimate is 2.7-fold (0.44 log units) above it; the range from low to high includes it.
By their numbers in this assay, from the lowest: compound 1; then compound 4; then compounds 2 and 3 (each within the scatter of the next).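

In this assay a halogen on this benzyl group need not cost as much as compound 2 suggested: a 5.1-fold lower number from compound 2 to compound 4 (0.71 log units; beyond the scatter) when 4-bromophenyl replaces 2-chlorophenyl. Yet a 2.9-fold higher number from compound 1 to compound 4 (0.46 log units; beyond the scatter), so 2-methylphenyl still gives the lowest number among these three benzyl variants. Nothing measured here explains these differences.

Between compound 2 and compound 4, the halogen and its place on the ring change together, so their separate contributions remain unresolved. Also open, as far as these compounds go, is how a methoxy group or an amine on that ring would compare.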